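The source may hold more compounds than are shown below. What is called first, only, known or untested is meant among the compounds shown, and "the series" means these compounds.

Measured in a functional assay on the whole organism with Rattus norvegicus as the target; on this read-out higher numbers stand for an effect only at larger amounts of compound and lower numbers for an effect already at smaller amounts:
- Compound 1 `O=C(O)c1cc(-c2ccccc2)ccc1O`: 54 mg/kg
- Compound 2 `O=C(O)c1cc(-c2ccc(F)cc2)ccc1O`: 14 mg/kg

Of these two compounds, compound 2 holds the lower number, 14 mg/kg, and so shows its effect at the smaller dose. Compound 3 `Cc1cc(F)ccc1-c1ccc(O)c(C(=O)O)c1` departs from it by methyl in place of hydrogen on an aromatic carbon. The new group sits ortho to a large group and meta to a fluoro group. Among the compounds with values here, only one measured step is available, a 3.9-fold lower number from compound 1 to compound 2 (0.59 log units; beyond the scatter), a modest change that came with fluoro in place of hydrogen. Within the data shown here, it concerns a different group, so it bears on the new change only loosely, and no measured step involves methyl. From the compounds shown here alone, it suggests only that a single small substitution can move this assay modestly, while the direction for methyl remains open. The expected result is therefore little change, with a 1.1-fold higher number from compound 2 to compound 3 (0.06 log units; within the scatter) as the estimate. For compound 3 the estimated value is 16 mg/kg, with an expected range from 6 mg/kg to 42 mg/kg.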

Compound 3, dose for half-maximal effect: 76 mg/kg
Estimate against measurement, compound 3: 4.8-fold (0.68 log units) below; measured number outside the range, above it.
By their numbers in this assay, from the lowest: compound 2; then compounds 1 and 3 (each within the scatter of the next).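

In this assay, methyl in place of hydrogen on an aromatic carbon, ortho to a large group and meta to a fluoro group, gave a 5.4-fold higher number from compound 2 to compound 3 (0.73 log units; beyond the scatter) and so undid the gain in dose seen with fluoro. That earlier step, a 3.9-fold lower number from compound 1 to compound 2 (0.59 log units; beyond the scatter), ran the other way, so a single small substitution on this ring can move the number in either direction. Nothing available accounts for the effect of the methyl group.

From the compounds shown here alone, it remains open whether this result belongs to methyl itself or would follow from any group at this place, such as chloro or methoxy. Going by these compounds, it also remains open whether methyl would give a similar step without the fluoro group present.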